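Arylpiperazine amide series: whole-animal minimum effective dose notes

The source may report more compounds than this note shows. Statements on the series, on what has been measured and on what is new or still open speak of the compounds shown alone.

Measured so far:
compound 1 `CC1(c2ccccc2)CC(=O)N(CC(=O)N2CCN(c3ccccc3F)CC2)C1=O`: 300 mg/kg
compound 2 `COc1cccc(N2CCN(C(=O)CN3C(=O)CC(C)(c4ccccc4)C3=O)CC2)c1`: "not active" (no number reported)

Within the data shown here, compound 1 is the only member of the series with a number. In a functional assay on the whole organism (strain CD-1) with Mus musculus as the target, with a stated time of 2 h (on this read-out lower numbers stand for an effect already at smaller amounts and higher numbers for an effect only at larger amounts of compound), compound 1 gives 300 mg/kg. Compound 2 carries a different group on the same ring nitrogen, and in this assay compound 2 is recorded as "not active" (no number reported), with no number behind it. Among the measured compounds shown here, no step between two numbered compounds can therefore be sized, and compound 1 stands alone on the scale.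

Compound 3 `CC1(c2ccccc2)CC(=O)N(CC(=O)N2CCN(c3ccc(Cl)c(Cl)c3)CC2)C1=O` is not yet measured. It differs from compound 1 in one place: 3,4-dichlorophenyl in place of 2-fluorophenyl on an amine nitrogen in a ring. For the measured compounds named here, with no measured step to lean on, the expected step of no change at the digits printed from compound 1 to compound 3 (within the scatter) is none beyond the scatter, and it is an estimate only. For compound 3 the expected value in this assay is 300 mg/kg, with a range from 100 mg/kg to 1000 mg/kg. An outcome without a number remains a real possibility for compound 3, because compound 2 in this assay gives "not active" (no number reported).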

Compound 3, minimum effective dose: "not active" (no number reported)
For compound 3 the study gives words and no number, and the estimate cannot be compared.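

No new step can be read in this assay: compound 1 gives 300 mg/kg, whereas compound 3 is recorded as "not active" (no number reported), so the change from 2-fluorophenyl to 3,4-dichlorophenyl has no size. The compounds shown leave open how other groups on that amine nitrogen would read out on this scale. Nothing available accounts for the result of compound 3.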